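Series notes: from compound 3 to compound 4

The compounds below may be only part of what the source reports. "The series", "measured", "known", "first", "only" and "open" are said of these compounds alone.

Compound 1 `CCc1nc(N)nc(N)c1-c1ccc(NCc2ccc([N+](=O)[O-])cc2)cc1` gives 11 nM in an in vitro assay on CHOK cells for displacement of a labelled ligand from growth hormone secretagogue receptor type 1 (Homo sapiens); on this read-out higher numbers stand for weaker inhibition and lower numbers for stronger inhibition. Compound 2 `CCc1nc(N)nc(N)c1-c1ccc(NCc2cc(F)c(S(=O)(=O)C(F)(F)F)c(F)c2)cc1` gives 21 nM in this assay. Within the data shown here, compound 3 `Nc1nc(N)c(-c2ccc(NCc3ccc([N+](=O)[O-])cc3)cc2)c(COCc2ccccc2)n1` gives 0.2 nM in this assay, the lowest number of the three; the only measured step, a 55-fold lower number from compound 1 to compound 3 (1.74 log units; beyond the scatter), concerns benzyloxy in place of methyl on a saturated chain carbon bound to an aromatic carbon. Compound 4 `Nc1nc(N)c(-c2ccc(CNc3ccc([N+](=O)[O-])cc3)cc2)c(COCc2ccccc2)n1` keeps that group and differs from compound 3 in one place: ((4-nitrophenyl)amino)methyl in place of (4-nitrobenzyl)amino on an aromatic carbon. Among the measured compounds shown here, no measured step touches this change, so the series gives no guide to its size or direction. The step is estimated as a 10-fold higher number from compound 3 to compound 4 (1.00 log units; beyond the scatter), a modest weakening held with wide uncertainty. Compound 4 is therefore expected at 2 nM, with a range from 0.3 nM to 15 nM in this assay.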

Compound 4, half-maximal inhibitory concentration: 0.8 nM
The estimate for compound 4 lay 2.5-fold (0.40 log units) above the measured number; the range from low to high includes it.
By their numbers in this assay, from the lowest: compound 3; then compound 4; then compounds 1 and 2 (each within the scatter of the next).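

In this assay the core tolerates the same atoms joined differently: ((4-nitrophenyl)amino)methyl in place of (4-nitrobenzyl)amino gives a 4.0-fold higher number from compound 3 to compound 4 (0.60 log units; beyond the scatter) on this aromatic carbon. The change is modest, yet it lies beyond the scatter, so the way this group is joined counts here even though the leaving and entering groups match in atom count and kind. No measurement shown explains the step. Open, going by these compounds, is whether the same change gives a similar step with ethyl in place of benzyloxymethyl. Also open, on these data alone, is how an amide or a longer chain would compare at this position.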